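From ethyl to pyrimidin-2-yl on a ring amine nitrogen

The compounds below may be only part of what the source reports. "The series", "measured", "known", "first", "only" and "open" are said of these compounds alone.

Of the compounds shown here, three have been measured in a functional assay on MGC-803 cells (Homo sapiens) for inhibition, read by MTT assay, with a stated time of 72 h (on this read-out higher numbers stand for weaker inhibition and lower numbers for stronger inhibition), so far.
- compound 1 `FC(F)(F)c1ccc(CSc2nc(N3CCNCC3)cc(C(F)(F)F)n2)cc1` gives 5870 nM
- compound 2 `CCN1CCN(c2cc(C(F)(F)F)nc(SCc3ccc(C(F)(F)F)cc3)n2)CC1` gives 25600 nM
- compound 3 `FC(F)(F)c1ccc(CSc2nc(N3CCN(c4ccccc4)CC3)cc(C(F)(F)F)n2)cc1` gives 35200 nM

Compound 2 stands level with compound 3 at the weaker end of this small set, and compound 1 is the strongest of the three. The change from compound 2 to compound 4 `FC(F)(F)c1ccc(CSc2nc(N3CCN(c4ncccn4)CC3)cc(C(F)(F)F)n2)cc1` is pyrimidin-2-yl in place of ethyl on an amine nitrogen in a ring and puts pyrimidin-2-yl in place of ethyl on an amine nitrogen in a ring. Going by the values given here, three measured steps bear on it. Ethyl in place of hydrogen gave a 4.4-fold higher number from compound 1 to compound 2 (0.64 log units; beyond the scatter) and phenyl in place of hydrogen gave a 6.0-fold higher number from compound 1 to compound 3 (0.78 log units; beyond the scatter) as two modest steps. Phenyl in place of ethyl gave a 1.4-fold higher number from compound 2 to compound 3 (0.14 log units; within the scatter) and is the closest precedent, as it also puts an aromatic ring in place of ethyl. Among the compounds with values here, no pyrimidin-2-yl compound has been measured, so the precedent is only partial. No step beyond the scatter is therefore expected in this assay for this replacement. The estimated step is a 1.1-fold lower number from compound 2 to compound 4 (0.03 log units; within the scatter) and its direction is not expected to be clear. For compound 4 the expected value is 24000 nM with an estimated range of 7000 nM to 60000 nM around it.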

Compound 4, half-maximal inhibitory concentration: 35200 nM
Compound 4: the middle estimate sits 1.5-fold (0.17 log units) below what was measured, and the stated range covers the measured number.
By their numbers in this assay, from the lowest: compound 1; then compounds 2, 3 and 4 (each within the scatter of the next).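

In this assay, pyrimidin-2-yl on the amine nitrogen in a ring cannot be told apart from the groups already tried there: replacing ethyl gives a 1.4-fold higher number from compound 2 to compound 4 (0.14 log units; within the scatter), and replacing phenyl gives no change at the digits printed from compound 3 to compound 4 (within the scatter). Its two ring nitrogens and two hydrogen-bond acceptors therefore leave no mark on this read-out compared with phenyl, while the step from the unsubstituted nitrogen is a 6.0-fold higher number from compound 1 to compound 4 (0.78 log units; beyond the scatter), so ethyl, phenyl and pyrimidin-2-yl all stand beyond the scatter from compound 1 and within it of one another. Nothing available accounts for this pattern.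

On these data alone, it remains open whether a methyl, an acetyl or a hydroxyethyl chain on this nitrogen would stay with compound 1 or join the other three. A longer chain ending in an amine or a carboxylic acid is equally unresolved.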